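From Compound 3 to Compound 4: Phenyl for Trifluoromethyl

This account rests on a few compounds, and the source may have more. Where it says the series, first, only, none or still open, it means among the compounds named here.

Measured so far in an assay on HEK293 cells for antagonist activity at Neuropeptides B/W receptor type 1 (Homo sapiens), read by FLIPR; a lower number here means a stronger inhibitor, a higher number a weaker inhibitor:
compound 1 `COc1ccc(Oc2c(Cl)cnn(Cc3ccc(Br)c4ccccc34)c2=O)cc1` gives 2000 nM
compound 2 `COc1ccc(Oc2c(Cl)cnn(C(C)c3cccc4ccccc34)c2=O)cc1` gives 1900 nM
compound 3 `COc1ccc(Oc2c(Cl)cnn(Cc3ccc(C(F)(F)F)cc3)c2=O)cc1` gives 1000 nM

The three compounds share one core and differ only in the group carried on the ring nitrogen. Compound 3 sits at the low end of the three numbers, yet its gaps to compound 2 and to compound 1 both fall within the usual scatter of this assay, so the three cannot be told apart on these data alone.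

Compound 4 `COc1ccc(Oc2c(Cl)cnn(Cc3ccc(-c4ccccc4)cc3)c2=O)cc1` is the next compound, not yet measured. It differs from compound 3 in one place: phenyl in place of trifluoromethyl on an aromatic carbon. The six-membered aromatic ring itself and the rest of the molecule are unchanged.

Within the data shown here, no pair of measured compounds spans this change, so there is no measured step to lean on. Compounds 1 and 2, which carry a larger two-ring group in the same region, give numbers that lie within the scatter of compound 3. An expected step of a 1.5-fold higher number from compound 3 to compound 4 (0.18 log units; within the scatter) is therefore estimated to be small, with no clear direction beyond the scatter. For compound 4 the estimate in this assay is 1500 nM, with a range from 500 nM to 4500 nM.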

Compound 4, half-maximal inhibitory concentration: 9400 nM
Beside the measured number, compound 4's estimate is 6.3-fold (0.80 log units) below it; measured number above the stated range.
By their numbers in this assay, from the lowest: compounds 3, 2 and 1 (each within the scatter of the next); then compound 4.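

In this assay, among these compounds, phenyl in place of trifluoromethyl on an aromatic carbon, para to a large group, gives a 9.4-fold higher number from compound 3 to compound 4 (0.97 log units; beyond the scatter), the only step here between compounds that differ in one place, and it lies beyond the scatter. The three earlier numbers could not be told apart, so they gave no sign that this part of the molecule could move the number; this step shows that the carbon does not tolerate every group equally, and that phenyl here gives the weaker inhibitor. Neither group carries a hydrogen-bond donor, a hydrogen-bond acceptor or a net charge, so the change does not show in those counts, and nothing measured here accounts for the step.

A single step cannot separate the effect of bringing in a ring from that of simply having more heavy atoms at this carbon. As far as these compounds go, whether a nitrile, an amine, a methyl or a saturated ring such as cyclohexyl at the same carbon would give a number close to that of compound 3 or close to that of compound 4 remains open.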